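This account rests on a few compounds, and the source may have more. Where it says the series, first, only, none or still open, it means among the compounds named here.

Compound 1 `O=C(Nc1cccc(-c2oc3cc(-c4ccc(F)cc4)ccc3c(=O)c2O)c1)c1ccc(Br)cc1`: 25400 nM
Compound 2 `Cc1cc(C(=O)Nc2cccc(-c3oc4cc(-c5ccc(F)cc5)ccc4c(=O)c3O)c2)ccc1F`: 12100 nM
Compound 3 `COc1ccc(C(=O)Nc2cccc(-c3oc4cc(-c5ccc(F)cc5)ccc4c(=O)c3O)c2)c(F)c1`: 15300 nM

These three compounds share one core and differ only in the aryl group attached to the carbonyl carbon of the amide. Measured in a functional assay on GTL 16 cells for antiproliferative activity against GTL 16 cell line (Homo sapiens), read by CCK-8 assay, with a stated time of 72 h (on this read-out lower numbers stand for stronger inhibition and higher numbers for weaker inhibition), compound 3 holds the second highest of the three numbers, but its distance to either neighbour is small: the steps to it read a 1.3-fold higher number from compound 2 to compound 3 (0.10 log units; within the scatter) and a 1.7-fold lower number from compound 1 to compound 3 (0.22 log units; within the scatter), and neither leaves the scatter. Within the data shown here, only one step among the measured compounds does so, a 2.1-fold lower number from compound 1 to compound 2 (0.32 log units; beyond the scatter), and even that one is modest.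

Compound 4 `O=C(Nc1cccc(-c2oc3cc(-c4ccc(F)cc4)ccc3c(=O)c2O)c1)c1cc(F)cc(F)c1` is the next member of the series. The change from compound 3 is 3,5-difluorophenyl in place of 2-fluoro-4-methoxyphenyl on a carbonyl carbon. Every step observed so far is a swap at this very position, and together they span little more than the scatter. There is therefore no reason to expect a large move for compound 4; the step from compound 3 is estimated as a 1.0-fold higher number from compound 3 to compound 4 (0.02 log units; within the scatter), which would leave it within the scatter. In this assay compound 4 is accordingly expected at about 16000 nM, within a range from 7000 nM to 36000 nM.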

Compound 4, half-maximal inhibitory concentration: 7410 nM
Beside the measured number, compound 4's estimate is 2.2-fold (0.33 log units) above it; the range from low to high includes it.
By their numbers in this assay, from the lowest: compounds 4, 2, 3 and 1 (each within the scatter of the next, the first and the last beyond it).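

The swap at this position reaches beyond the scatter in a second pair of compounds: in this assay, replacing 2-fluoro-4-methoxyphenyl with 3,5-difluorophenyl on the carbonyl carbon gives a 2.1-fold lower number from compound 3 to compound 4 (0.31 log units; beyond the scatter), a modest step. Among these compounds, the widest gap so far at this position is now a 3.4-fold lower number from compound 1 to compound 4 (0.54 log units; beyond the scatter), which is still modest but shows that the aryl group on the amide carbonyl can shift the number by more than the earlier compounds did. Against the group in compound 2, however, the change gives a 1.6-fold lower number from compound 2 to compound 4 (0.21 log units; within the scatter), so 3,5-difluorophenyl and 4-fluoro-3-methylphenyl cannot be told apart here, and no measurement shown explains any of these differences.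

Every group shown at this position is a substituted phenyl ring, so the effect of something quite different there, such as a cyclohexyl ring, a pyridine ring, a carboxylic acid or an amine, remains open. Also open, from the compounds shown here alone, is whether a plain phenyl ring would match these fluorinated groups, and whether changes elsewhere on the shared core would move the number further than swaps at this position have.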